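Tetrazole-to-imidazole swap on the thioether of compound 3

The compounds below may be only part of what the source reports. "The series", "measured", "known", "first", "only" and "open" are said of these compounds alone.

Measured compounds:
compound 1 `Cc1ccc2oc(SCC(=O)Nc3ccc(-c4nc(-c5ccccc5)c(-c5ccccc5)n4C)cc3)nc2c1` gives 37.7%
compound 2 `Cn1c(-c2ccc(NC(=O)CSc3nc4ccccc4s3)cc2)nc(-c2ccccc2)c1-c1ccccc1` gives 47.2%
compound 3 `Cn1nnnc1SCC(=O)Nc1ccc(-c2nc(-c3ccccc3)c(-c3ccccc3)n2C)cc1` gives 72.5%

In a functional assay on HT-29 cells (Homo sapiens) for cytotoxicity, read by MTT assay, with a stated time of 24 h, tested at 16 ug/mL (a higher number here means a stronger effect of the compound at the concentration tested, a lower number a weaker effect), compound 3 stands highest of the three numbers; the nearest is compound 2 and the furthest compound 1, and both gaps lie beyond the scatter, as the steps of a number 25.3 percentage points higher from compound 2 to compound 3 (beyond the scatter) and a number 34.8 percentage points higher from compound 1 to compound 3 (beyond the scatter) show. Between compound 1 and compound 2 the step of a number 9.5 percentage points higher from compound 1 to compound 2 (within the scatter) lies within the scatter.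

Compound 4 `Cn1ccnc1SCC(=O)Nc1ccc(-c2nc(-c3ccccc3)c(-c3ccccc3)n2C)cc1` is not yet measured. It differs from compound 3 by 1-methyl-1H-imidazol-2-yl in place of 1-methyl-1H-tetrazol-5-yl on a sulfur. The two measured steps that bear on it both replaced a bicyclic ring on the sulfur with the 1-methyl-1H-tetrazol-5-yl group and both raised the read-out, one modestly and one largely. For the measured compounds named here, no measured step compares one five-membered ring with another on this sulfur, so the direction of the step to compound 4 is open. Given that compound 3 sits highest, a step back toward the values of compound 2 is expected, a number 14.5 percentage points lower from compound 3 to compound 4 (beyond the scatter), though it may stay within the scatter. Compound 4 is estimated at 58%, within 40% to 76%.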

Compound 4, a percentage reported as activity, at one concentration (the size of the read-out at that concentration, not a potency): 36.5%
Compound 4: the middle estimate sits 21.5 percentage points above what was measured, outside the stated range (below it).
By their numbers in this assay, from the lowest: compounds 4, 1 and 2 (each within the scatter of the next, the first and the last beyond it); then compound 3.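

In this assay, for the compounds shown here, no earlier step compared two five-membered rings on this sulfur, and 1-methyl-1H-imidazol-2-yl in place of 1-methyl-1H-tetrazol-5-yl gives a number 36 percentage points lower from compound 3 to compound 4 (beyond the scatter) here. The two groups match in heavy atoms and differ in their carbon and nitrogen counts and hydrogen-bond acceptors, so a single five-membered aromatic ring on the sulfur does not by itself give the high read-out of compound 3. Against the bicyclic groups, the imidazolyl group gives a number 10.7 percentage points lower from compound 2 to compound 4 (beyond the scatter) and a number 1.2 percentage points lower from compound 1 to compound 4 (within the scatter) so the gain seen among these compounds belongs to the tetrazolyl group alone.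

From the compounds shown here alone, whether a 1-methyl-1H-1,2,4-triazol-5-yl group on the sulfur would keep the read-out of compound 3 or fall toward that of compound 4 remains open, as does how these single-concentration read-outs relate to potency. No supporting data bear on why the two rings differ.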